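Sulfonamide nitrogen substituent in a PFKFB3 series: compound 4

A few compounds are considered here, and "the series" means these few. Any claim that something is new, unique, unknown or untested is made for them only; others in the source may bear on it.

Measured so far:
Compound 1 `CN1CCC(CNS(=O)(=O)c2ccccc2Nc2cc(-c3ccc4ccn(C)c4c3)c3nccnc3c2)C1`: 11 nM
Compound 2 `Cn1ccc2ccc(-c3cc(Nc4ccccc4S(=O)(=O)Nc4cncnc4)cc4nccnc34)cc21`: 1690 nM
Compound 3 `CN(Cc1cncnc1)S(=O)(=O)c1ccccc1Nc1cc(-c2ccc3ccn(C)c3c2)c2nccnc2c1`: 62 nM

All three share one core and differ only in the group on the sulfonyl sulfur; the read-out is an assay for inhibition of 6-phosphofructo-2-kinase/fructose-2,6-bisphosphatase 3 (Homo sapiens), read by ADP-Glo, with a stated time of 2 h; a lower number here means a stronger inhibitor, a higher number a weaker inhibitor. Compound 3 stands second of the three in this assay, with the step of a 5.6-fold higher number from compound 1 to compound 3 (0.75 log units; beyond the scatter) setting it apart from compound 1, and the step of a 27-fold lower number from compound 2 to compound 3 (1.44 log units; beyond the scatter) setting it far apart from compound 2. The worst number belongs to compound 2, where the pyrimidine sits directly on the sulfonamide nitrogen: a 150-fold higher number from compound 1 to compound 2 (2.19 log units; beyond the scatter).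

Compound 4 `Cn1cc(CNS(=O)(=O)c2ccccc2Nc2cc(-c3ccc4ccn(C)c4c3)c3nccnc3c2)cn1` is not yet measured. Its change from compound 3 is ((1-methyl-1H-pyrazol-4-yl)methyl)amino in place of methyl((pyrimidin-5-yl)methyl)amino on a sulfonyl sulfur. Going by the values given here, two measured steps bear on it. The large loss in a 150-fold higher number from compound 1 to compound 2 (2.19 log units; beyond the scatter) concerns a heteroaryl placed directly on the nitrogen, which compound 4 does not do; the methylene-linked arrangement in compound 3 recovers most of that, as a 27-fold lower number from compound 2 to compound 3 (1.44 log units; beyond the scatter) shows. Compound 4 keeps the methylene link, exchanges the six-membered ring for the five-membered one, and returns to a sulfonamide bearing a hydrogen, as in compound 1. Among the compounds with values here, a modest move toward the number of compound 1 is therefore expected in this assay, a 2.1-fold lower number from compound 3 to compound 4 (0.32 log units; beyond the scatter), though the ring exchange itself has no measured precedent here. For compound 4 the expected value is 30 nM, within 8 nM to 120 nM.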

Compound 4, half-maximal inhibitory concentration: 38 nM
The estimate for compound 4 lay 1.3-fold (0.10 log units) below the measured number; low and high end bracket the measured number.
By their numbers in this assay, from the lowest: compound 1; then compounds 4 and 3 (each within the scatter of the next); then compound 2.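

In this assay, putting ((1-methyl-1H-pyrazol-4-yl)methyl)amino in place of methyl((pyrimidin-5-yl)methyl)amino on a sulfonyl sulfur gives a 1.6-fold lower number from compound 3 to compound 4 (0.21 log units; within the scatter) and so this position tolerates either ring group on the methylene link, although this exchange alters the ring and the substitution on the nitrogen together, and the two contributions cannot be told apart. Compound 4 also allows a comparison of ring alone with compound 1, since both carry a hydrogen on the sulfonamide nitrogen and the same methylene link: 1-methyl-1H-pyrazol-4-yl in place of 1-methylpyrrolidin-3-yl gives a 3.5-fold higher number from compound 1 to compound 4 (0.54 log units; beyond the scatter) and this aromatic ring therefore retains much, but not all, of the number of compound 1, while a 44-fold lower number from compound 2 to compound 4 (1.65 log units; beyond the scatter) keeps compound 2 well apart from the methylene-linked compounds. No available evidence accounts for any of these differences.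

The compounds shown leave open what the methyl on the sulfonamide nitrogen of compound 3 contributes by itself, which the pyrimidin-5-ylmethyl group with a hydrogen on that nitrogen would settle. Also open, from the compounds shown here alone, is whether an open-chain amine such as a 2-(dimethylamino)ethyl group on the same nitrogen would match compound 1, or whether the pyrrolidine ring is needed.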